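From Difluorocyclohexyl to Acetylpiperidinyl on the Sulfonyl Sulfur

The source may hold more compounds than are shown below. What is called first, only, known or untested is meant among the compounds shown, and "the series" means these compounds.

Among the compounds with values here, in a functional assay on A2780 cells (Homo sapiens) for cytotoxicity, read by sulforhodamine B assay, with a stated time of 72 h (on this read-out lower numbers stand for stronger inhibition and higher numbers for weaker inhibition), compound 1 `CCCn1cc(S(=O)(=O)c2ccc(CNC(=O)N3Cc4ccncc4C3)cc2)cn1` gives 7.3 nM and compound 2 `O=C(NCc1ccc(S(=O)(=O)C2CCC(F)(F)CC2)cc1)N1Cc2ccncc2C1` gives 13 nM so compound 2 stands within the scatter of the only other measured number. Compound 3 `CC(=O)N1CCC(S(=O)(=O)c2ccc(CNC(=O)N3Cc4ccncc4C3)cc2)CC1` keeps the shared core and carries 1-acetylpiperidin-4-yl in place of 4,4-difluorocyclohexyl on a sulfonyl sulfur. That change is 1-acetylpiperidin-4-yl in place of 4,4-difluorocyclohexyl on a sulfonyl sulfur and it has not yet been tested. Within the data shown here, one measured step bears on it, because a 1.8-fold higher number from compound 1 to compound 2 (0.25 log units; within the scatter) came from exchanging the group on that same sulfonyl sulfur. A single step is thin evidence, but it gives no reason to expect a large shift. The expected change is a 1.1-fold higher number from compound 2 to compound 3 (0.03 log units; within the scatter) and no move beyond the scatter is anticipated in either direction. For compound 3 the estimate in this assay is 14 nM with an expected range from 5 nM to 40 nM in this read-out.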

Compound 3, half-maximal inhibitory concentration: 110 nM
For compound 3 the middle estimate is 7.9-fold (0.90 log units) below the measured one, and the stated range ends below it.
By their numbers in this assay, from the lowest: compounds 1 and 2 (each within the scatter of the next); then compound 3.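

In this assay, the sulfonyl sulfur proves sensitive to the group it carries: 1-acetylpiperidin-4-yl in place of 4,4-difluorocyclohexyl gives an 8.5-fold higher number from compound 2 to compound 3 (0.93 log units; beyond the scatter), and in place of 1-propyl-1H-pyrazol-4-yl it gives a 15-fold higher number from compound 1 to compound 3 (1.18 log units; beyond the scatter), whereas the exchange between the other two groups gave a 1.8-fold higher number from compound 1 to compound 2 (0.25 log units; within the scatter). The earlier pair therefore did not show the full span at this position, and the entering group differs from 4,4-difluorocyclohexyl in its ring hetero atom, its double bond outside aromatic rings and its hydrogen-bond acceptor. Nothing measured here accounts for the higher number of compound 3.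

The compounds shown do not separate the contribution of the acetyl group from that of the ring nitrogen. A piperidin-4-yl group with a free amine, or a tetrahydropyran-4-yl group with a ring oxygen, would bear on that question.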